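Pentyl in place of phenyl on the shared core

The source may report more compounds than this note shows. Statements on the series, on what has been measured and on what is new or still open speak of the compounds shown alone.

In a functional assay on HL-60 cells (Homo sapiens) for antiproliferative activity, read by MTT assay (on this read-out higher numbers stand for weaker inhibition and lower numbers for stronger inhibition), compound 2 `O[C@@H]1[C@@H](OCc2ccccc2)[C@H](OCc2ccccc2)[C@@H](COCc2ccccc2)O[C@H]1c1ccccc1` gives 26300 nM, the higher of two numbers, while compound 1 `O[C@@H]1[C@@H](OCc2ccccc2)[C@H](OCc2ccccc2)[C@@H](COCc2ccccc2)O[C@H]1Cc1ccccc1` gives 8700 nM. Compound 3 `CCCCC[C@@H]1O[C@H](COCc2ccccc2)[C@@H](OCc2ccccc2)[C@H](OCc2ccccc2)[C@H]1O` carries pentyl in place of phenyl on a saturated ring carbon. Among the compounds with values here, the one measured step on that carbon, a 3.0-fold higher number from compound 1 to compound 2 (0.48 log units; beyond the scatter), is modest and puts phenyl in place of benzyl. No open chain has been measured there, so this guide is indirect. The expected change is a modest step to a lower number, estimated as a 2.2-fold lower number from compound 2 to compound 3 (0.34 log units; beyond the scatter). For compound 3 the expected value is 12000 nM, within a range of 4000 nM to 35000 nM.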

Compound 3, half-maximal inhibitory concentration: "not active" (no number reported)
Compound 3: no number reported, so the estimate cannot be set against anything.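

Within the data shown here, compound 3 is reported as "not active" with no number, so no step from compound 2 to compound 3 can be read. From the compounds shown here alone, how far pentyl shifts the value from that of phenyl stays open. No measured evidence bears on this result.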